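Phenyl for furan-2-yl on a shortened coumarin-linked chalcone

A few compounds are considered here, and "the series" means these few. Any claim that something is new, unique, unknown or untested is made for them only; others in the source may bear on it.

Measured so far:
compound 1 `COc1cc(/C=C/C(=O)/C=C/c2ccccc2)ccc1OCc1cn(CCCCCOc2cc(=O)oc3ccccc23)nn1`: 26%
compound 2 `COc1cc(/C=C/C(=O)/C=C/c2ccco2)ccc1OCc1cn(CCCCOc2cc(=O)oc3ccccc23)nn1`: 49%

In a functional assay on THP-1 cells (Homo sapiens) for inhibition, read by sulforhodamine B assay, with a stated time of 48 h, tested at 50 uM (a lower number here means less inhibition of growth, a higher number more inhibition of growth at the concentration tested), compound 2 gives 49%, the higher of the two numbers, while compound 1 gives 26%, a gap beyond the usual scatter. Compound 3 `COc1cc(/C=C/C(=O)/C=C/c2ccccc2)ccc1OCc1cn(CCCCOc2cc(=O)oc3ccccc23)nn1` differs from compound 2 in one place: phenyl in place of furan-2-yl on a double-bonded chain carbon bound to a double-bonded chain carbon. For the measured compounds named here, no step between measured compounds covers this exchange, so the account leans on what compound 1 shows. Because compound 1 gives 26%, a decrease beyond the scatter is expected; the step from compound 2 to compound 3 is estimated at a number 16 percentage points lower from compound 2 to compound 3 (beyond the scatter). Compound 3 is expected to give 33%, within 18% to 48%.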

Compound 3, percent growth inhibition at one concentration: 36%
Compound 3: middle estimate off by 3 percentage points, on the low side; measured number inside the range.
By their numbers in this assay, from the lowest: compounds 1 and 3 (each within the scatter of the next); then compound 2.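

In this assay, for the compounds shown here, the exchange of furan-2-yl for phenyl on a double-bonded chain carbon bound to a double-bonded chain carbon gives a number 13 percentage points lower from compound 2 to compound 3 (beyond the scatter) and is the first reading of this change with all else held constant. Compound 1 and compound 3, which differ only in the linking chain, lie within the scatter of each other, so most of the gap between compound 1 and compound 2 appears alongside the ring exchange. Nothing measured here accounts for the step.

On these data alone, whether thiophen-2-yl, pyridin-2-yl or a phenyl bearing an amine would stand nearer furan-2-yl or phenyl remains open.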